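A bromo for a nitro on the sulfonyl group

A few compounds are considered here, and "the series" means these few. Any claim that something is new, unique, unknown or untested is made for them only; others in the source may bear on it.

In a functional assay on A549 cells (Homo sapiens) for antiproliferative activity, read by MTT assay, with a stated time of 24 h (a lower number here means a stronger inhibitor, a higher number a weaker inhibitor), compound 1 (`Cc1ccc(-c2nn(-c3ccccc3)cc2-c2nc3ccccc3[nH]2)cc1`) gives 4010 nM while compound 2 (`Cc1ccc(-c2nn(-c3ccccc3)cc2-c2nc3ccccc3n2S(=O)(=O)c2ccc(Br)cc2)cc1`) gives 1860 nM and compound 3 (`O=[N+]([O-])c1ccc(S(=O)(=O)n2c(-c3cn(-c4ccccc4)nc3-c3ccc(F)cc3)nc3ccccc32)cc1`) gives 1030 nM in the same test. Compound 3 lies within the scatter of compound 2 and beyond the scatter below compound 1.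

The open case is compound 4 (`O=S(=O)(c1ccc(Br)cc1)n1c(-c2cn(-c3ccccc3)nc2-c2ccc(F)cc2)nc2ccccc21`), which has bromo in place of nitro on an aromatic carbon, turning (4-nitrophenyl)sulfonyl into (4-bromophenyl)sulfonyl: bromo in place of nitro on an aromatic carbon is the whole change from compound 3.

For the measured compounds named here, no measured step tests this swap directly. Going by the values given here, the only step available is a 2.2-fold lower number from compound 1 to compound 2 (0.33 log units; beyond the scatter) on placing (4-bromophenyl)sulfonyl on an aromatic nitrogen, and that modest move concerns adding the sulfonyl group rather than exchanging its substituent. Compound 4 carries the same bromo group as compound 2 but also differs from it elsewhere, and in this assay compound 2 shows 1860 nM. Among the compounds with values here, that value stays within the scatter of the one for compound 3, so no large move is expected. What is expected is a 1.4-fold higher number from compound 3 to compound 4 (0.13 log units; within the scatter) and so no change beyond the scatter. For compound 4 the estimated value is 1400 nM with an expected range from 700 nM to 2800 nM in this test.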

Compound 4, half-maximal inhibitory concentration: 1720 nM
Beside the measured number, compound 4's estimate is 1.2-fold (0.09 log units) below it; measured number inside the range.
By their numbers in this assay, from the lowest: compounds 3, 4 and 2 (each within the scatter of the next); then compound 1.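

In this assay, bromo in place of nitro on an aromatic carbon, para to a large group, gives a 1.7-fold higher number from compound 3 to compound 4 (0.22 log units; within the scatter), so this position tolerates the exchange of (4-nitrophenyl)sulfonyl for (4-bromophenyl)sulfonyl without a change that can be told from the scatter, although the group that leaves has 3 heavy atoms and 2 hydrogen-bond acceptors and the one that enters has 1 heavy atom and none. A second single change, fluoro in place of methyl on an aromatic carbon, gives a 1.1-fold lower number from compound 2 to compound 4 (0.03 log units; within the scatter), so with the bromo group held fixed that exchange also leaves the number within the scatter. The data offer no explanation for either result.

Left open is whether this position would stay as unresponsive with an amine, a carboxylic acid or a methoxy group in place of the bromo, as the two groups compared here say nothing about those. Also open, going by these compounds, is whether a carbonyl in place of the sulfonyl would keep the number in this range.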